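A Methyl on a Phenol Oxygen, Tested Twice

The source may hold more compounds than are shown below. What is called first, only, known or untested is meant among the compounds shown, and "the series" means these compounds.

Compound 1 `O=C(Nc1cccc(-n2cc(-c3ccncc3)c(-c3cc(O)cc(Cl)c3)n2)c1)Nc1ccc(Cl)c(C(F)(F)F)c1` and compound 2 `COc1cc(Cl)cc(-c2nn(-c3cccc(NC(=O)Nc4ccc(Cl)c(C(F)(F)F)c4)c3)cc2-c2ccncc2)c1` share one core; compound 3 `O=C(Nc1cccc(-n2cc(-c3ccncc3)c(-c3cc(O)cc(Cl)c3)n2)c1)c1cc(C(F)(F)F)cc(C(F)(F)F)c1` and compound 4 `COc1cc(Cl)cc(-c2nn(-c3cccc(NC(=O)c4cc(C(F)(F)F)cc(C(F)(F)F)c4)c3)cc2-c2ccncc2)c1` share another, and the difference between the two cores is not broken down here. In a functional assay on NCI-H460 cells (Homo sapiens) for inhibition, read by sulforhodamine B assay, with a stated time of 48 h, tested at 10 uM (a lower number here means a stronger effect, a higher number a weaker effect of the compound at the concentration tested), compound 1 gives 3.75% and compound 2 gives 2.76%, so the change methyl in place of hydrogen on an oxygen on an aromatic ring made a step of a number 1 percentage points lower from compound 1 to compound 2 (within the scatter). Compound 3 gives 19.9% in this assay. The change from compound 3 to compound 4, (methyl in place of hydrogen on an oxygen on an aromatic ring), is the same change at the same place, only made on the other core. Because the step of a number 1 percentage points lower from compound 1 to compound 2 (within the scatter) was so small, compound 4 is expected to stay close to compound 3, with an estimated step of a number 0.9 percentage points lower from compound 3 to compound 4 (within the scatter). The estimate for compound 4 in this assay is 19%, expected between 8% and 32%.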

Compound 4, a percentage reported as activity, at one concentration (the size of the read-out at that concentration, not a potency): 41%
Compound 4: middle estimate off by 22 percentage points, on the low side; measured number outside the range, above it.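

In this assay the change from hydroxy to methoxy gives a number 21.1 percentage points higher from compound 3 to compound 4 (beyond the scatter) and so a weaker effect at the concentration tested. The same change therefore behaves differently on the two cores: the same change on two cores in this assay, a number 1 percentage points lower (within the scatter) from compound 1 to compound 2 and a number 21.1 percentage points higher (beyond the scatter) from compound 3 to compound 4, 22.1 percentage points apart, beyond the scatter of two such steps. This shows that the near-absence of a step on the core of compound 1 did not carry over to the core of compound 3, but two pairs cannot explain the difference or predict the result on a further core.

The compounds shown leave open how an ethoxy group or an amine at this place would read on either core. They also leave open whether the two cores would differ in the same way in other cell lines.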